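Group on the aromatic nitrogen and liver microsomal clearance in one series

This account rests on a few compounds, and the source may have more. Where it says the series, first, only, none or still open, it means among the compounds named here.

Measured so far in an ADME assay on microsomes from liver (Homo sapiens) for metabolic stability; on this read-out lower numbers stand for slow clearance and higher numbers for fast clearance:
Compound 1, `CC(C)Cn1cc(-c2ccnc3[nH]c(C4CCN(CC(=O)N(C)C)CC4)cc23)ccc1=O`, gives 21 uL/min.
Compound 2, `CN(C)C(=O)CN1CCC(c2cc3c(-c4ccc(=O)n(C5CCOCC5)c4)ccnc3[nH]2)CC1`, gives 8.2 uL/min.
Compound 3, `CC(C)n1cc(-c2ccnc3[nH]c(C4CCN(CC(=O)N(C)C)CC4)cc23)ccc1=O`, reaches only the assay limit of < 3 uL/min.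

Compound 3 thus stands at the low end of the three; its value is a limit and not a number (the limit of < 3 uL/min in this assay, at which 1 of the 3 values shown sits). The two steps that reach it both lower the read-out: an at least 7.0-fold lower number from compound 1 to compound 3 (0.84 log units; beyond the scatter) and an at least 2.7-fold lower number from compound 2 to compound 3 (0.43 log units; beyond the scatter). The smaller isopropyl on the aromatic nitrogen therefore goes with the slowest clearance seen, while isobutyl and oxan-4-yl give measurable numbers.

Compound 4, `CN(C)C(=O)CN1CCC(c2cc3c(-c4ccc(=O)n(CCC5CCOCC5)c4)ccnc3[nH]2)CC1`, has not yet been measured. It differs from compound 3 by 2-(oxan-4-yl)ethyl in place of isopropyl on an aromatic nitrogen. The entering group is larger than either isobutyl or oxan-4-yl, both of which sit above compound 3 in this assay. A rise beyond the scatter is therefore expected, probably to somewhere between the values of compound 2 and compound 1, or above them. Compound 4 is expected to give 15 uL/min, with a range of 5 uL/min to 45 uL/min. The implied step is expected to be an at least 5.0-fold higher number from compound 3 to compound 4 (0.69 log units; beyond the scatter).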

Compound 4, intrinsic clearance in a liver preparation (reported as CLH), per the amount of preparation that the assay uses: 19 uL/min
Compound 4: middle estimate off by 1.3-fold (0.10 log units), on the low side; low and high end bracket the measured number.
By their numbers in this assay, from the lowest: compound 2; then compounds 4 and 1 (each within the scatter of the next). At a limit, below all of these: compound 3.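

In this assay, 2-(oxan-4-yl)ethyl on the aromatic nitrogen gives a measurable clearance that separates from both isopropyl and oxan-4-yl: an at least 6.3-fold higher number from compound 3 to compound 4 (0.80 log units; beyond the scatter), and a 2.3-fold higher number from compound 2 to compound 4 (0.36 log units; beyond the scatter). The first of these steps is only a bound, since compound 3 carries a limit and not a number: the limit of < 3 uL/min in this assay, at which 1 of the 4 values shown sits. The third step, a 1.1-fold lower number from compound 1 to compound 4 (0.04 log units; within the scatter), does not separate 2-(oxan-4-yl)ethyl from isobutyl, so an oxan ring on this nitrogen does not of itself give a lower read-out than an all-carbon group, and the same ring set directly on the nitrogen in compound 2 gives the lowest measured number of the series.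

The compounds shown leave open whether the low read-out of compound 3 extends to other small groups on this nitrogen, such as cyclopropyl, ethyl or tert-butyl. They also leave open whether an oxygen-bearing open chain such as 2-methoxyethyl would stay with the lower or the higher compounds, and how far below the others compound 3 truly lies.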